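The source may hold more compounds than are shown below. What is called first, only, known or untested is meant among the compounds shown, and "the series" means these compounds.

Measured so far: compound 1 `COc1cccc(CNC(=O)c2nc(Br)c3cccnc3c2N[C@H]2CC[C@H](N)CC2)c1`, 6000 nM in a functional assay on HCT-116 cells (Homo sapiens) for cytotoxicity, read by MTT assay, with a stated time of 72 h; a lower number here means a stronger inhibitor, a higher number a weaker inhibitor; compound 2 `COC(=O)c1nc(Br)c2cccnc2c1N[C@H]1CC[C@H](N)CC1`, "not determined" (no result reported) in this assay.

Compound 2 thus stands nowhere on the numbers: it has no value, and compound 1 alone offers a figure, a weak one in this assay. Compound 3 `N[C@H]1CC[C@H](Nc2c(C(=O)Nc3ccccc3)nc(Br)c3cccnc23)CC1` differs from compound 2 by a single change, (anilino in place of methoxy on a carbonyl carbon). No measured pair sizes this step, so the expectation in this assay rests on compound 1 only: potency near that of compound 1, with no direction favoured beyond the scatter. Compound 3 is estimated at 5000 nM, expected range 1200 nM to 20000 nM.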

Compound 3, half-maximal inhibitory concentration: 2000 nM
Compound 3: middle estimate off by 2.5-fold (0.40 log units), on the high side; measured number inside the range.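

In this assay, the step of a 3.0-fold lower number from compound 1 to compound 3 (0.48 log units; beyond the scatter) shows that the group on the amide-type nitrogen matters: phenyl in place of 3-methoxybenzyl moves the number beyond the scatter. The step from methoxy to anilino cannot be read, as compound 2 has no value. Nothing measured here accounts for the shift. Whether the shift comes from the methoxy or from the extra carbon of the benzyl stays open, since plain benzyl is not among these compounds. A carboxylic acid in place of the methoxycarbonyl also remains untested in what is shown here.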